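A few compounds are considered here, and "the series" means these few. Any claim that something is new, unique, unknown or untested is made for them only; others in the source may bear on it.

Measured compounds in a physicochemical assay for solubility, using the shake flask method, measured as kinetic solubility, with a stated time of 20 h, at pH 2; a lower number here means a less soluble compound, a higher number a more soluble compound

compound 1 `COc1ccnc(Nc2cc3[nH]c(-c4cccc(C(F)(F)F)c4)nc3cn2)c1` gives < 5000 nM (a limit)
compound 2 `CN1CCN(c2ccc(Nc3cc4[nH]c(-c5cccc(C(F)(F)F)c5)nc4cn3)nc2)CC1` gives 190000 nM
compound 3 `FC1(F)CCC(c2nc3cnc(Nc4ccc(C(F)(F)F)cn4)cc3[nH]2)C1` gives 185000 nM

Going by the values given here, the entry for compound 1 is a limit of the assay and not a number, so only two numbers can be compared. Compound 3 (185000 nM) and compound 2 (190000 nM) lie within the scatter of each other, and neither ranks over the other.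

The next step starts from compound 3. Compound 4 `CC1(c2nc3cnc(Nc4ccc(C(F)(F)F)cn4)cc3[nH]2)CC1` has 1-methylcyclopropyl in place of 3,3-difluorocyclopentyl on an aromatic carbon of a five-membered aromatic ring with 2 nitrogen, between two ring nitrogen atoms (1-methylcyclopropyl in place of 3,3-difluorocyclopentyl on an aromatic carbon). The rest of the structure stays the same.

Among the compounds with values here, the series offers no measured step between compounds that differ in one place, so no measured size can be carried over to this change. In this assay no step beyond the scatter is expected, with only a slight lean towards a lower number. This expectation takes compound 3 at 185000 nM as its starting point. The estimated step is small (a 1.1-fold lower number from compound 3 to compound 4 (0.04 log units; within the scatter)) and the expected range is kept wider on the low side. Compound 4 is estimated at 170000 nM (expected range 60000 nM to 215000 nM).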

Compound 4, solubility: 200000 nM
The estimate for compound 4 lay 1.2-fold (0.07 log units) below the measured number; measured number inside the range.
By their numbers in this assay, from the lowest: compounds 3, 2 and 4 (each within the scatter of the next). At a limit, below all of these: compound 1.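

In this assay, going by these compounds alone, the first step readable between compounds that differ in one place is a 1.1-fold higher number from compound 3 to compound 4 (0.03 log units; within the scatter), with 1-methylcyclopropyl in place of 3,3-difluorocyclopentyl on an aromatic carbon between two ring nitrogen atoms. At this position, going from a five-membered ring of carbon only that carries two fluorine atoms to a three-membered ring of carbon only, with fewer heavy atoms and no fluorine, leaves the read-out within the scatter in this one comparison. Compound 1 holds a limit of the assay and not a number, and it differs from compound 3 and compound 4 in more than one place, so it gives no measure of this change: the limit of < 5000 nM in this assay, at which 1 of the 4 values shown sits.

From the compounds shown here alone, whether a group such as an amine or a carboxylic acid on this aromatic carbon would give a step beyond the scatter stays open. Going by these compounds, the trifluoromethyl-bearing part is the same in compound 3 and compound 4, so it also stays open whether this change would give a similar step with a different group there.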